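Swapping trifluoromethyl for hydroxy on a triazole-linked triterpenoid

The compounds below may be only part of what the source reports. "The series", "measured", "known", "first", "only" and "open" are said of these compounds alone.

Of the compounds shown here, three built on the same triterpenoid skeleton have been tested in a functional assay on MCF7 cells (Homo sapiens) for cytotoxicity, read by MTT assay, with a stated time of 48 h; on this read-out lower numbers stand for stronger inhibition and higher numbers for weaker inhibition. Compound 1 `CC(C)=CCC/C(C)=C/CC/C(C)=C/CC[C@@H]1[C@@]2(C)CC/C(=N\OCc3cn(-c4cccc(C(F)(F)F)c4)nn3)C(C)(C)[C@@H]2CC[C@@]1(C)O` gives 21400 nM. Compound 2 `CC(C)=CCC/C(C)=C/CC/C(C)=C/CC[C@@H]1[C@@]2(C)CC/C(=N\OCc3cn(-c4cccc(O)c4)nn3)C(C)(C)[C@@H]2CC[C@@]1(C)O` differs from it by one change, (hydroxy in place of trifluoromethyl on an aromatic carbon), and gives 9900 nM; that change made a 2.2-fold lower number from compound 1 to compound 2 (0.33 log units; beyond the scatter). Compound 3 `CC(C)=CCC/C(C)=C/CC/C(C)=C/CC[C@@H]1[C@@]2(C)C/C(=C\c3ccc(OCc4cn(-c5cccc(C(F)(F)F)c5)nn4)cc3)C(=O)C(C)(C)[C@@H]2CC[C@@]1(C)O` carries the same trifluoromethyl-bearing phenyl group on a different core, and the difference between the two cores is not broken down here; in this assay compound 3 gives 13800 nM.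

Compound 4 `CC(C)=CCC/C(C)=C/CC/C(C)=C/CC[C@@H]1[C@@]2(C)C/C(=C\c3ccc(OCc4cn(-c5cccc(O)c5)nn4)cc3)C(=O)C(C)(C)[C@@H]2CC[C@@]1(C)O` is not yet measured. It stands to compound 3 as compound 2 stands to compound 1: the change is hydroxy in place of trifluoromethyl on an aromatic carbon, occurring at the same place, so it is the same change seen once already.

If it behaves as it did from compound 1 to compound 2, the expected step is a 2.0-fold lower number from compound 3 to compound 4 (0.29 log units; within the scatter), resting on the single earlier step of a 2.2-fold lower number from compound 1 to compound 2 (0.33 log units; beyond the scatter), with the different core and the usual scatter widening the range. Compound 4 is therefore expected to give about 7000 nM in this assay, estimated to fall between 3000 nM and 16000 nM.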

Compound 4, half-maximal inhibitory concentration: 45500 nM
Estimate against measurement, compound 4: 6.5-fold (0.81 log units) below, outside the stated range (above it).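

On the other core, the same swap of trifluoromethyl for hydroxy produced a 3.3-fold higher number from compound 3 to compound 4 (0.52 log units; beyond the scatter) in this assay, so the change did not carry across and its direction reversed: the same change on two cores in this assay, a 2.2-fold lower number (0.33 log units; beyond the scatter) from compound 1 to compound 2 and a 3.3-fold higher number (0.52 log units; beyond the scatter) from compound 3 to compound 4, 7.1-fold (0.85 log units) apart, beyond the scatter of two such steps. In this series, then, the effect of the swap depends on the core that carries it, and a step seen on one core is a poor guide to the step on the other. This does not show why the two cores differ, since each direction rests on a single pair of compounds and the difference between the cores is not broken down, nor does it show how the swap would behave on a third core.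

The compounds shown have only trifluoromethyl or hydroxy at this place on the phenyl ring, so it remains open how a methoxy group, a fluorine atom or an amine would fare on each core. Those groups could show whether the reversal is particular to this pair of groups or extends more widely.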